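The compounds below may be only part of what the source reports. "The series", "measured", "known", "first", "only" and "open" are said of these compounds alone.

Compound 2, `COc1cc(-c2nn(-c3cccc(NC(=O)Nc4ccc(Cl)c(Cl)c4)c3)cc2-c2ccncc2)ccc1Cl`, gives 859 nM in a functional assay on RXF 393 cells (Homo sapiens) for inhibition, read by sulforhodamine B assay, with a stated time of 48 h (a lower number here means a stronger inhibitor of growth, a higher number a weaker inhibitor of growth), the lower of the two numbers measured; compound 1, `O=C(Nc1cccc(-n2cc(-c3ccncc3)c(-c3ccc(Cl)c(O)c3)n2)c1)Nc1cccc(C(F)(F)F)c1`, gives 3020 nM in this assay, a gap beyond the scatter. Compound 3, `O=C(Nc1cccc(-n2cc(-c3ccncc3)c(-c3ccc(Cl)c(O)c3)n2)c1)Nc1ccc(Cl)c(Cl)c1`, differs from compound 2 in one place: hydrogen in place of methyl on an oxygen on an aromatic ring. Among the compounds with values here, no single step of this kind has been measured here, and compound 1 differs from compound 3 in two places, so its value is only a loose guide. Compound 3 is expected to give 1500 nM (range 600 nM to 4000 nM), a step from compound 2 estimated as a 1.7-fold higher number from compound 2 to compound 3 (0.24 log units; within the scatter), a modest weakening.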

Compound 3, concentration for 50% growth inhibition: 1000 nM
Compound 3: middle estimate off by 1.5-fold (0.18 log units), on the high side; the range from low to high includes it.
By their numbers in this assay, from the lowest: compounds 2 and 3 (each within the scatter of the next); then compound 1.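

In this assay, swapping methoxy for hydroxy on the 4-chloro-3-methoxyphenyl group leaves the number within the scatter, with a 1.2-fold higher number from compound 2 to compound 3 (0.07 log units; within the scatter), so this position tolerates either group here. The change at the other end of the molecule counts for more: 3,4-dichlorophenyl in place of 3-(trifluoromethyl)phenyl on the amide-type nitrogen gives a 3.0-fold lower number from compound 1 to compound 3 (0.48 log units; beyond the scatter). Nothing available explains either step. As far as these compounds go, whether an amine or a longer chain such as ethoxy at the methoxy position would also be tolerated remains open, as does the effect of a single chlorine on the phenyl group on the amide-type nitrogen.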